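Trimming the pyrazole substituent: from nitrile to bare ring

The source may hold more compounds than are shown below. What is called first, only, known or untested is meant among the compounds shown, and "the series" means these compounds.

Compound 3 `CCCC(Oc1ccc(-n2cc(C#N)cn2)cc1)c1ccc(C(=O)NCCC(=O)O)cc1` gives 4100 nM in an assay on cells for displacement of a labelled ligand from Glucagon receptor (Homo sapiens), in the presence of a further agent that is not named here (on this read-out lower numbers stand for stronger inhibition and higher numbers for weaker inhibition), the second highest of three numbers. Compound 1 `CCCC(Oc1ccc(-n2cc3ccccc3n2)cc1)c1ccc(C(=O)NCCC(=O)O)cc1` gives 290 nM and compound 2 `CCCC(Oc1ccc(-n2cc(C(=O)N(C)C)cn2)cc1)c1ccc(C(=O)NCCC(=O)O)cc1` gives 6500 nM. The step of a 1.6-fold lower number from compound 2 to compound 3 (0.20 log units; within the scatter) lies within the scatter, whereas a 22-fold higher number from compound 1 to compound 2 (1.35 log units; beyond the scatter) and a 14-fold higher number from compound 1 to compound 3 (1.15 log units; beyond the scatter) are large. Compound 4 `CCCC(Oc1ccc(-n2cccn2)cc1)c1ccc(C(=O)NCCC(=O)O)cc1` carries the change (hydrogen in place of cyano on an aromatic carbon), that is, 4-cyano-1H-pyrazol-1-yl to 1H-pyrazol-1-yl. Among the compounds with values here, the only step bearing on the substituent at that aromatic carbon, from compound 2 to compound 3, was within the scatter, so removing the group altogether is expected to give no step beyond the scatter, with a wide range to allow for the unknown. Compound 4 is therefore estimated at 4000 nM (range 1300 nM to 12000 nM), a step of a 1.0-fold lower number from compound 3 to compound 4 (0.01 log units; within the scatter).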

Compound 4, inhibition constant: 4100 nM
Estimate against measurement, compound 4: 1.0-fold (0.01 log units) below, and the stated range covers the measured number.
By their numbers in this assay, from the lowest: compound 1; then compounds 3, 4 and 2 (each within the scatter of the next).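

Removing the nitrile leaves the number in this assay unchanged (no change at the digits printed from compound 3 to compound 4 (within the scatter)), and replacing dimethylcarbamoyl with hydrogen also gives a step within the scatter (a 1.6-fold lower number from compound 2 to compound 4 (0.20 log units; within the scatter)), so hydrogen, cyano and dimethylcarbamoyl cannot be told apart at this aromatic carbon. Only the 2H-indazol-2-yl group stands apart from the unsubstituted 1H-pyrazol-1-yl (a 14-fold higher number from compound 1 to compound 4 (1.15 log units; beyond the scatter)). Nothing given here explains either outcome.

On these data alone, whether an amine, a carboxylic acid or a phenyl group on this carbon would shift the number remains open. So does whether a group on another carbon of the pyrazole would close the gap to the 2H-indazol-2-yl compound.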